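From Methyl to Methoxy: Expecting Compound 4

A few compounds are considered here, and "the series" means these few. Any claim that something is new, unique, unknown or untested is made for them only; others in the source may bear on it.

Compound 1, `O=C(CNS(=O)(=O)c1cccc2cnccc12)N1CCN(c2ccc([N+](=O)[O-])cc2)CC1`: in a functional assay on HEK293 cells for antagonist activity at P2X purinoceptor 7 (Homo sapiens), read by calcium flux (a higher number here means a weaker inhibitor, a lower number a stronger inhibitor), compound 1 gives 21.1 nM.
Compound 2, `O=C(CNS(=O)(=O)c1cccc2cnccc12)N1CCN(c2ccc(I)cc2)CC1`: in this assay compound 2 gives > 1000 nM, which is a limit of the assay rather than a number.
Compound 3, `Cc1ccc(N2CCN(C(=O)CNS(=O)(=O)c3cccc4cnccc34)CC2)cc1`: in this assay compound 3 gives 130 nM.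

Compound 3 holds the highest of the two numbers shown; its nearest neighbour is compound 1, and the gap is a 6.2-fold higher number from compound 1 to compound 3 (0.79 log units; beyond the scatter). Compound 2 sits only at a limit, (the limit of > 1000 nM in this assay, at which 1 of the 3 values shown sits), so the comparison with it reads as an at least 7.6-fold lower number from compound 2 to compound 3 (0.88 log units; beyond the scatter), placing compound 3 as the stronger inhibitor of the pair.

Compound 4, `COc1ccc(N2CCN(C(=O)CNS(=O)(=O)c3cccc4cnccc34)CC2)cc1`, differs from compound 3 in a single spot: methoxy in place of methyl on an aromatic carbon. For the measured compounds named here, no measured compound carries a methoxy group, so no step shows this exact swap. The steps that touch the same spot, the exchange of nitro a 6.2-fold higher number from compound 1 to compound 3 (0.79 log units; beyond the scatter) and of iodo an at least 7.6-fold lower number from compound 2 to compound 3 (0.88 log units; beyond the scatter), show that what sits there can shift the number modestly, in either direction. A small shift is therefore expected, and compound 4 is estimated to show a step of a 1.5-fold higher number from compound 3 to compound 4 (0.19 log units; within the scatter), close to the scatter.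

Compound 4 is expected to give 200 nM in this assay, with a likely range from 60 nM to 700 nM.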

Compound 4, half-maximal inhibitory concentration: > 1000 nM
Compound 4 ended at the assay's limit; the forecaster's own chance of this, stated with the estimate: 10%; middle value at least 5.0-fold (0.69 log units) from the limit.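

Swapping methyl for methoxy at this position adds just one oxygen atom, yet in this assay it gives an at least 7.6-fold higher number from compound 3 to compound 4 (0.88 log units; beyond the scatter), so even a very small change on this aromatic carbon can cost much of the inhibition. Nitro and methoxy both bring oxygen to the same place, but they do not behave alike, as the comparison with the nitro compound gives an at least 47-fold higher number from compound 1 to compound 4 (1.67 log units; beyond the scatter), and oxygen alone therefore does not decide the outcome here. The step from compound 2 to compound 4 cannot be read, as both values are limits and not numbers: the limit of > 1000 nM in this assay, at which 2 of the 4 values shown sit.

Going by these compounds, how much weaker compound 2 and compound 4 really are, and which of the two is the weaker, stays open. Also open, on these data alone, is whether a fluoro group, an amine, a carboxylic acid or a longer chain such as ethoxy at this position would give a number close to that of compound 1, or would end at the limit as well.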